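Cytotoxicity notes: furan-2-yl for pyridin-2-yl on compound 2

This account rests on a few compounds, and the source may have more. Where it says the series, first, only, none or still open, it means among the compounds named here.

Measured in an ADME assay on RAW264.7 cells (Mus musculus) for cytotoxicity, read by MTT assay, with a stated time of 72 h, tested at 100 uM; on this read-out lower numbers stand for a weaker effect and higher numbers for a stronger effect at the one concentration tested:
- compound 1 `O=C(Cn1c(=O)oc2cc(Cl)ccc21)Nc1nc2ccccc2s1` gives 52.5%
- compound 2 `O=C(Cn1c(=O)oc2cc([N+](=O)[O-])ccc21)NCc1ccccn1` gives 33.4%
- compound 3 `O=C(Cn1c(=O)oc2ccccc21)Nc1nc2ccc([N+](=O)[O-])cc2s1` gives 19.2%

Compound 2 holds the second highest of the three numbers. Its nearest neighbour is compound 3, whose number lies lower by a gap beyond the scatter; its furthest is compound 1, whose number lies higher, again beyond the scatter. Among the measured compounds shown here, no pair among the three measured compounds differs in a single place, so no single-point step between measured compounds can be read from these numbers; each measured compound differs from the others at more than one site, and only their bare values can be set beside one another.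

Compound 4 `O=C(Cn1c(=O)oc2cc([N+](=O)[O-])ccc21)NCc1ccco1` has not yet been measured. It is compound 2 with one change: furan-2-yl in place of pyridin-2-yl on a saturated chain carbon bound to an amide-type nitrogen. The rest of compound 2 is kept. Without any measured step that isolates a change of this kind, the expectation for this assay rests on compound 2 alone, and the step from compound 2 to compound 4 is expected to be a number 2.4 percentage points lower from compound 2 to compound 4 (within the scatter), which is taken as no step beyond the scatter. Compound 4 is therefore estimated at 31%, within a range from 16% to 46%.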

Compound 4, a percentage reported as inhibition, at one concentration (the size of the read-out at that concentration, not a potency): 60.1%
Compound 4: the middle estimate sits 29.1 percentage points below what was measured, outside the stated range (above it).
By their numbers in this assay, from the lowest: compound 3; then compound 2; then compounds 1 and 4 (each within the scatter of the next).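

In this assay, among the compounds shown here, the saturated chain carbon bound to an amide-type nitrogen is the first place where a single change can be read: furan-2-yl in place of pyridin-2-yl gives a number 26.7 percentage points higher from compound 2 to compound 4 (beyond the scatter), with the rest of compound 2 kept. The read-out therefore responds to the ring at this place, even though pyridin-2-yl and furan-2-yl carry the same counts of hydrogen-bond donors and acceptors and differ in ring size, hetero atom and heavy-atom count. Nothing measured on these compounds speaks to the origin of this step.

This single pair on the core of compound 2 leaves open whether the same change would give a step of similar size on the cores of compound 1 or compound 3, and steps involving those two compounds cannot be read. It also leaves open how this assay would respond at this place to thiophen-2-yl, plain phenyl, a longer chain between the ring and the amide-type nitrogen, or a simple aliphatic amine in place of the ring.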